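Lengthening the amide at the opposite end of the molecule

A few compounds are considered here, and "the series" means these few. Any claim that something is new, unique, unknown or untested is made for them only; others in the source may bear on it.

Compound 1 `CC(=O)NCCN(C)c1cccc(OCCCCCCNC(=O)Oc2cccc(-c3ccccc3)c2)c1` is the parent of this small group. In a functional assay on cells for agonist activity at melatonin receptor type 1B (Homo sapiens), read by GTPgammaS binding, with a stated time of 30 min (a higher number here means a larger maximal response, a lower number a smaller maximal response), compound 1 gives 0.75, the lowest of the three measured values. Compound 2 `CC(=O)NCCN(C)c1cccc(OCCCCCCNC(=O)Oc2cccc(-c3cccc(O)c3)c2)c1` gives 0.94 and compound 3 `CC(=O)NCCN(C)c1cccc(OCCCCCCNC(=O)Oc2cccc(-c3cccc(C(N)=O)c3)c2)c1` gives 1.01. Both measured steps alter the far aromatic ring: a number 0.19 higher from compound 1 to compound 2 (beyond the scatter) and a number 0.26 higher from compound 1 to compound 3 (beyond the scatter), while a number 0.070 higher from compound 2 to compound 3 (within the scatter).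

Compound 4 `CCC(=O)NCCN(C)c1cccc(OCCCCCCNC(=O)Oc2cccc(-c3ccccc3)c2)c1` changes a different place altogether: methyl in place of hydrogen on a saturated chain carbon bound to a carbonyl carbon. Among the compounds with values here, no measured step touches this position, so the measured steps give no direct guidance; they only show that the maximal response in this assay moves modestly, if at all, with single small changes elsewhere. A shift of one methyl at the amide end is therefore expected to leave the maximal response near that of compound 1, and the expected step is a number 0.030 higher from compound 1 to compound 4 (within the scatter). Compound 4 is thus estimated at 0.78, with a range from 0.55 to 1.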

Compound 4, intrinsic activity: the largest response reached, as a fraction of the reference agonist's: 0.88
Estimate against measurement, compound 4: 0.10 below, and the stated range covers the measured number.
By their numbers in this assay, from the lowest: compound 1; then compounds 4, 2 and 3 (each within the scatter of the next, the first and the last beyond it).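

Even a single methyl counts at the amide end: in this assay the change from acetamido to propanoylamino gives a number 0.13 higher from compound 1 to compound 4 (beyond the scatter) and so raises the maximal response by a modest amount. Within the data shown here, the earlier steps all altered the far aromatic ring, so this is the first measured sign that the opposite end of the molecule can also move this read-out. Nothing measured here explains the rise.

A single step cannot show how far this goes: a longer chain such as butanoyl, or a cyclopropyl group in the same place, might raise the response further or lower it. It also remains open whether the added methyl would combine with hydroxy or carbamoyl on the far ring, as no compound shown carries both changes.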